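Moving from 2,6-dimethylphenyl to 3,5-dimethylphenyl

The compounds below may be only part of what the source reports. "The series", "measured", "known", "first", "only" and "open" are said of these compounds alone.

Values so far in a functional assay on A-431 cells (Homo sapiens) for cytotoxicity; a lower number here means that less compound is needed, a higher number that more compound is needed for the effect 
- compound 1 `COC1=C(C)C(=O)/C(=C(O)/C=C/c2ccc(F)cc2)C(=O)C1(C)C` gives 4.1 ug/mL 
- compound 2 `COC1=C(C)C(=O)/C(=C(O)/C=C/c2c(C)cccc2C)C(=O)C1(C)C` gives 10.1 ug/mL 

Compound 2 holds the higher of the two numbers in this assay. Compound 3 `COC1=C(C)C(=O)/C(=C(O)/C=C/c2cc(C)cc(C)c2)C(=O)C1(C)C` is not yet measured and has 3,5-dimethylphenyl in place of 2,6-dimethylphenyl on a double-bonded chain carbon bound to a double-bonded chain carbon. Going by the values given here, one measured step bears on this place: a 2.5-fold higher number from compound 1 to compound 2 (0.39 log units; beyond the scatter). Among the compounds with values here, no measured pair isolates a shift of the methyl groups, so only a modest move toward a lower number is expected. The expected step is a 1.6-fold lower number from compound 2 to compound 3 (0.19 log units; within the scatter). For compound 3 the estimated value is 6.5 ug/mL, with an expected range from 2.8 ug/mL to 15 ug/mL.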

Compound 3, concentration for half-maximal effect: 4 ug/mL
Beside the measured number, compound 3's estimate is 1.6-fold (0.21 log units) above it; the range from low to high includes it.
By their numbers in this assay, from the lowest: compounds 3 and 1 (each within the scatter of the next); then compound 2.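

In this assay, moving the two methyl groups alone gives a 2.5-fold lower number from compound 2 to compound 3 (0.40 log units; beyond the scatter) at this place, so the arrangement of the methyl groups on the phenyl ring affects the number, not just their presence. The step to 3,5-dimethylphenyl from 4-fluorophenyl is a 1.0-fold lower number from compound 1 to compound 3 (0.01 log units; within the scatter) and separates these two groups in no way. No available evidence accounts for the difference between the two dimethylphenyl isomers.

Still open, from the compounds shown here alone, is whether a single methyl group on the phenyl ring would give a number like that of compound 2 or compound 3. Also open, going by these compounds, is how a phenyl ring carrying an amine or a carboxylic acid would read in this assay.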